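A few compounds are considered here, and "the series" means these few. Any claim that something is new, unique, unknown or untested is made for them only; others in the source may bear on it.

Measured so far:
Compound 1, `O=C(O)Cc1sc(C(c2ccc(F)cc2)c2ccc(F)cc2)nc1-c1ccc(Cl)cc1`, gives 180 nM in an in vitro functional assay on HEK285-7 cells for antagonist activity at prostaglandin D2 receptor 2 (Homo sapiens), read by BRET and beta-arrestin recruitment; a higher number here means a weaker inhibitor, a lower number a stronger inhibitor.
Compound 2, `O=C(O)Cc1sc(C(c2ccc(F)cc2)c2ccc(F)cc2)nc1-c1ccccc1`, gives 240 nM in this assay.
Compound 3, `O=C(O)Cc1sc(C(c2ccccc2)c2ccccc2)nc1-c1ccc(F)cc1`, gives 77 nM in this assay.

Compound 2 and compound 1 differ in one place: chloro in place of hydrogen on an aromatic carbon. That change produced a 1.3-fold lower number from compound 2 to compound 1 (0.12 log units; within the scatter). Compound 3 carries a different core from compound 2; the difference between the two cores is not broken down here. Compound 4, `O=C(O)Cc1sc(C(c2ccccc2)c2ccc(Cl)cc2)nc1-c1ccc(F)cc1`, has not yet been measured in this assay. It differs from compound 3 by the same change, at the same kind of place: chloro in place of hydrogen on an aromatic carbon. Because the earlier change gave a 1.3-fold lower number from compound 2 to compound 1 (0.12 log units; within the scatter), a step of similar, small size is expected here: a 1.2-fold lower number from compound 3 to compound 4 (0.07 log units; within the scatter). Compound 4 is therefore estimated at 65 nM in this assay, with the result most likely falling between 30 nM and 140 nM.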

Compound 4, half-maximal inhibitory concentration: 79 nM
For compound 4 the middle estimate is 1.2-fold (0.08 log units) below the measured one; the measured number falls inside the stated range.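

Chloro in place of hydrogen, here phenyl to 4-chlorophenyl, gave a 1.0-fold higher number from compound 3 to compound 4 (0.01 log units; within the scatter) in this assay, so compound 3 and compound 4 cannot be told apart. The two steps for this change, on two different cores, also cannot be told apart: the same change on two cores in this assay, a 1.3-fold lower number (0.12 log units; within the scatter) from compound 2 to compound 1 and a 1.0-fold higher number (0.01 log units; within the scatter) from compound 3 to compound 4, 1.4-fold (0.14 log units) apart, within the scatter of two such steps. This suggests that the small size of the step carried over between these two cores, but two pairs make no general rule, and they do not show that it would stay as small on another core.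

The compounds shown leave open what a larger group, such as methoxy or nitrile, would do in place of the chloro. They also leave open what an amide would do in place of the carboxylic acid.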